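The source may hold more compounds than are shown below. What is called first, only, known or untested is meant among the compounds shown, and "the series" means these compounds.

Compound 2 `CC(C)[C@H](NC(=O)COc1cccc2ccccc12)C(=O)N[C@@H](CC(=O)O)C(=O)COc1cccc(F)c1` gives 12000 nM in a functional assay with Homo sapiens as the target; a higher number here means a weaker inhibitor, a lower number a stronger inhibitor. Its only comparator, compound 1 `CC(C)[C@H](NC(=O)COc1cccc2ccccc12)C(=O)N[C@@H](CC(=O)O)C(=O)COc1ccc([N+](=O)[O-])cc1`, gives 22800 nM in this assay, and the step of a 1.9-fold lower number from compound 1 to compound 2 (0.28 log units; within the scatter) lies within the scatter, so the two numbers cannot be told apart. Compound 3 `CC(C)[C@H](NC(=O)COc1cccc2ccccc12)C(=O)N[C@@H](CC(=O)O)C(=O)COc1c(F)c(F)c(F)c(F)c1F` has not yet been measured. It differs from compound 2 by 2,3,4,5,6-pentafluorophenyl in place of 3-fluorophenyl on an oxygen on a saturated carbon. For the measured compounds named here, the only measured step that bears on this place is a 1.9-fold lower number from compound 1 to compound 2 (0.28 log units; within the scatter), an exchange of the aryl group on the same oxygen on a saturated carbon, and it stayed within the scatter; no measured step tests a ring carrying more than one fluorine. Compound 3 is therefore expected to move little from compound 2, with a step of a 1.2-fold lower number from compound 2 to compound 3 (0.08 log units; within the scatter) that need not rise beyond the scatter. Compound 3 is estimated at 10000 nM in this assay, with a range from 3500 nM to 30000 nM.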

Compound 3, half-maximal inhibitory concentration: 8890 nM
For compound 3 the middle estimate is 1.1-fold (0.05 log units) above the measured one, within the range that was stated.
By their numbers in this assay, from the lowest: compounds 3, 2 and 1 (each within the scatter of the next, the first and the last beyond it).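

In this assay, the exchange of 3-fluorophenyl for 2,3,4,5,6-pentafluorophenyl on the oxygen gives a 1.3-fold lower number from compound 2 to compound 3 (0.13 log units; within the scatter), so a ring carrying five fluorines cannot be told apart from a ring carrying one. For the compounds shown here, the comparison with the 4-nitrophenyl group gives a 2.6-fold lower number from compound 1 to compound 3 (0.41 log units; beyond the scatter), the only step at this place that lies beyond the scatter, and it remains modest. Nothing available explains either step.

On these data alone, it stays open whether an unsubstituted phenyl, a pyridine ring or a longer saturated chain on the same oxygen would keep, lose or improve on this level of inhibition. The compounds shown also leave open how a change outside this place, in the shared core, would affect the numbers in this assay.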